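Swapping an aryl group for a pyridinylmethyl group

The compounds below may be only part of what the source reports. "The series", "measured", "known", "first", "only" and "open" are said of these compounds alone.

Of the compounds shown here, three sharing one core have been measured in a functional assay on A-375 cells (Homo sapiens) for antiproliferative activity, read by CCK-8 assay, with a stated time of 72 h, tested at 8 uM; a lower number here means a weaker effect, a higher number a stronger effect of the compound at the concentration tested. Compound 1 `Nc1ccccc1NC(=O)c1ccc(CSC(=S)N2CCN(c3ccc(Cl)cc3)CC2)cc1` gives 29%. Compound 2 `COc1ccc(N2CCN(C(=S)SCc3ccc(C(=O)Nc4ccccc4N)cc3)CC2)cc1` gives 35.9%, the second highest of the three numbers. Compound 3 `CC1CCCCN1C(=S)SCc1ccc(C(=O)Nc2ccccc2N)cc1` gives 85.2%, well beyond the scatter from compound 2. Among the compounds with values here, the only single-point step among them, a number 6.9 percentage points higher from compound 1 to compound 2 (within the scatter), shows that exchanging one small group for another on the aromatic ring of the large substituent leaves the read-out unchanged within the scatter.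

Compound 4 `Nc1ccccc1NC(=O)c1ccc(CSC(=S)N2CCN(Cc3ccncc3)CC2)cc1` has not yet been measured. Its change from compound 2 is (pyridin-4-yl)methyl in place of 4-methoxyphenyl on an amine nitrogen in a ring. Within the data shown here, no measured step covers this kind of replacement, so the small step from compound 1 to compound 2 bears on it only loosely, and the high number of compound 3, which carries a different amine altogether, gives no direct guide either. The step is therefore expected to be modest, a number 9.1 percentage points higher from compound 2 to compound 4 (within the scatter), with direction uncertain. Compound 4 is estimated at 45%, ranging from 25% to 70%.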

Compound 4, a percentage reported as inhibition, at one concentration (the size of the read-out at that concentration, not a potency): 89.5%
Compound 4: middle estimate off by 44.5 percentage points, on the low side, and the stated range ends below it.
By their numbers in this assay, from the lowest: compounds 1 and 2 (each within the scatter of the next); then compounds 3 and 4 (each within the scatter of the next).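

Within the data shown here, compounds 1 and 2 showed only that exchanging one small group on the aromatic ring leaves the read-out within the scatter. In this assay the step from 4-methoxyphenyl to (pyridin-4-yl)methyl is a number 53.6 percentage points higher from compound 2 to compound 4 (beyond the scatter) and the step from 4-chlorophenyl to the same group is a number 60.5 percentage points higher from compound 1 to compound 4 (beyond the scatter) on the same amine nitrogen in the ring. Replacing the whole group at this position can therefore move the read-out far more than changing a small group on its aromatic ring.

This replacement changes two things at once: the aromatic ring now holds a nitrogen, and a methylene link joins it to the amine, so a benzyl group at this position would be needed to tell the two apart. Nothing available here explains the size of the step.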